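Swapping the indole nitrogen substituent: from chloro-benzoyl to benzyl

A few compounds are considered here, and "the series" means these few. Any claim that something is new, unique, unknown or untested is made for them only; others in the source may bear on it.

Compound 2 `O=C1COCCN1c1ccc(/N=C\c2cn(C(=O)c3ccc(Cl)cc3)c3ccccc23)cc1` is a close relative of compound 1 `O=C1COCCN1c1ccc(/N=C\c2c[nH]c3ccccc23)cc1`, differing only in the group on an aromatic nitrogen. In an ADME assay on BV-2 cells (Mus musculus) for cytotoxicity, read by MTT assay, with a stated time of 48 h, tested at 0.5 uM (a higher number here means a weaker effect of the compound at the concentration tested, a lower number a stronger effect), compound 1 gives 104%, and in this assay compound 2 gives 95.2%. Compound 2 thus holds the lower of the two numbers, though the step of a number 8.8 percentage points lower from compound 1 to compound 2 (within the scatter) stays within the scatter, so the two results cannot be told apart. Compound 3 `O=C1COCCN1c1ccc(/N=C\c2cn(Cc3ccccc3)c3ccccc23)cc1` arises from compound 2 by a single change: benzyl in place of (4-chlorophenyl)carbonyl on an aromatic nitrogen. Going by the values given here, no measured step matches this exchange; the only step recorded, from compound 1 to compound 2, changed the same nitrogen substituent and moved the read-out by an amount inside the scatter. On that basis a shift of a number 1.8 percentage points higher from compound 2 to compound 3 (within the scatter) is expected, meaning no change beyond the scatter. Compound 3 is therefore estimated at 97%, with a range from 85% to 108%.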

Compound 3, a percentage reported as activity, at one concentration (the size of the read-out at that concentration, not a potency): 86.6%
The estimate for compound 3 lay 10.4 percentage points above the measured number, and the stated range covers the measured number.
By their numbers in this assay, from the lowest: compounds 3, 2 and 1 (each within the scatter of the next, the first and the last beyond it).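

In this assay the group on the aromatic nitrogen now shows a step beyond the scatter, a number 17.4 percentage points lower from compound 1 to compound 3 (beyond the scatter) with benzyl in place of hydrogen, so a group at this position can move the read-out modestly. Exchanging (4-chlorophenyl)carbonyl for benzyl gives a number 8.6 percentage points lower from compound 2 to compound 3 (within the scatter) and does not separate the two groups, even though only benzyl stands clearly apart from the hydrogen of compound 1, so the three compounds cannot be put in a firm order. Nothing available here explains this shift. As far as these compounds go, it remains open whether a methyl group, a longer chain ending in an amine, or a benzyl group carrying a chlorine would move the read-out further from that of compound 1. A single tested concentration also leaves open how the effect changes with dose.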